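A few compounds are considered here, and "the series" means these few. Any claim that something is new, unique, unknown or untested is made for them only; others in the source may bear on it.

In a functional assay on HCT-116 cells (Homo sapiens) for antiproliferative activity, read by CCK-8 assay, with a stated time of 72 h (on this read-out higher numbers stand for weaker inhibition and lower numbers for stronger inhibition), compound 1 (`Cc1ccc(Nc2nc(Cl)nc3c2ncn3Cc2ccc(C(=O)Nc3ccccc3N)cc2)cc1`) gives 580 nM and compound 2 (`Nc1ccccc1NC(=O)c1ccc(Cn2cnc3c(Nc4ccccc4)nc(Cl)nc32)cc1`) gives 1070 nM on the shared core. Compound 3 (`Nc1ccccc1NC(=O)c1ccc(Cn2cnc3c(Nc4cccc(Cl)c4)nc(Cl)nc32)cc1`) gives 2340 nM and holds the highest number of the three, which is the weakest inhibition so far. Compound 4 (`CN1CCN(c2nc(Cl)nc3c2ncn3Cc2ccc(C(=O)Nc3ccccc3N)cc2)CC1`) is still unmeasured and puts 4-methylpiperazin-1-yl in place of (3-chlorophenyl)amino on an aromatic carbon. Among the measured compounds shown here, no measured compound lacks an aromatic group on that nitrogen, so no measured step makes this replacement. For the measured compounds named here, the steps that bear on it only vary the phenyl group: a 1.8-fold higher number from compound 1 to compound 2 (0.27 log units; within the scatter) on losing the methyl, a 2.2-fold higher number from compound 2 to compound 3 (0.34 log units; beyond the scatter) on adding the chloro and a 4.0-fold higher number from compound 1 to compound 3 (0.61 log units; beyond the scatter) on exchanging one aryl group for the other. These steps are small and give little guide to direction. With compound 3 at 2340 nM at the top of the range, a slightly lower number is expected in this assay but no step beyond the scatter. The expected move is a 1.6-fold lower number from compound 3 to compound 4 (0.19 log units; within the scatter) on this estimate. Compound 4 is estimated at 1500 nM with an expected range of 400 nM to 5500 nM in this wide estimate.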

Compound 4, half-maximal inhibitory concentration: 310 nM
Compound 4: the middle estimate sits 4.8-fold (0.68 log units) above what was measured; the measured number lies below the stated range.
By their numbers in this assay, from the lowest: compounds 4, 1 and 2 (each within the scatter of the next, the first and the last beyond it); then compound 3.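

In this assay this position does not need an aromatic group on the nitrogen: 4-methylpiperazin-1-yl, a non-aromatic ring with 0 hydrogen-bond donors, is tolerated on this aromatic carbon, with a 7.5-fold lower number from compound 3 to compound 4 (0.88 log units; beyond the scatter) and a 3.5-fold lower number from compound 2 to compound 4 (0.54 log units; beyond the scatter) on the shared core. Against the 4-methylphenyl compound the change gives a 1.9-fold lower number from compound 1 to compound 4 (0.27 log units; within the scatter) and so does not separate the two groups. No measurement shown gives a reason for these steps.

Open, as far as these compounds go, is how piperazin-1-yl without the methyl, morpholin-4-yl, piperidin-1-yl or an open-chain dimethylamino group would read at this position. Also open, from the compounds shown here alone, is whether these steps hold when an amine replaces the chloro group on the shared core.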